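This account rests on a few compounds, and the source may have more. Where it says the series, first, only, none or still open, it means among the compounds named here.

In a functional assay on K562 cells (Homo sapiens) for cytotoxicity, read by MTT assay, with a stated time of 24 h (a lower number here means a stronger inhibitor, a higher number a weaker inhibitor), compound 1 `CN1C/C(=C\c2ccc(F)cc2)C(=O)/C(=C/c2cccc([N+](=O)[O-])c2)C1` gives 11300 nM, and compound 2 `CN1C/C(=C\c2cccc([N+](=O)[O-])c2)C(=O)/C(=C/c2ccc(Cl)c(Cl)c2)C1` gives 15500 nM. These two values lie within the scatter of each other, so the numbers do not separate compound 2 from compound 1.

The next compound is compound 3 `CN1C/C(=C\c2cccc(Br)c2)C(=O)/C(=C/c2cccc([N+](=O)[O-])c2)C1`. The structural change is 3-bromophenyl in place of 3,4-dichlorophenyl on a double-bonded chain carbon bound to a double-bonded ring carbon. The other aryl arm and the rest of the core stay as they are.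

Within the data shown here, only one measured step bears on this change. It is a 1.4-fold higher number from compound 1 to compound 2 (0.14 log units; within the scatter), a replacement at this same place, and it stays within the scatter. Among the measured compounds shown here, that single step is thin evidence, and no measured compound carries the 3-bromophenyl group. Even so, the step from compound 1 gives no reason to expect a large shift in this assay, so no change beyond the scatter is expected here. The expected step is a 1.2-fold lower number from compound 2 to compound 3 (0.08 log units; within the scatter), with no firm direction. For compound 3 the estimate is 13000 nM, with an expected range of 6000 nM to 28000 nM.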

Compound 3, half-maximal inhibitory concentration: 12200 nM
Estimate against measurement, compound 3: 1.1-fold (0.03 log units) above, and the stated range covers the measured number.
By their numbers in this assay, from the lowest: compounds 1, 3 and 2 (each within the scatter of the next).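

In this assay, the step of a 1.3-fold lower number from compound 2 to compound 3 (0.10 log units; within the scatter) and the step of a 1.1-fold higher number from compound 1 to compound 3 (0.03 log units; within the scatter) both stay within the scatter, so a third group at this place does not separate from either of the first two. Among these compounds, the exchange of 3,4-dichlorophenyl, with its two chlorine atoms, for 3-bromophenyl, with its single bromine, therefore gives no readable difference, and the three halogen-bearing phenyl groups on a double-bonded chain carbon bound to a double-bonded ring carbon now read alike in this assay, with no compound among them going against this. No supporting measurement is available to account for this flat reading.

As far as these compounds go, all three groups at this place are phenyl rings carrying halogen, so it stays open whether a phenyl ring bearing an amine or a carboxylic acid, or a longer chain in place of the ring, would give a step beyond the scatter. From the compounds shown here alone, it also stays open whether the other aryl arm, common to compound 1, compound 2 and compound 3, responds to replacement in the same flat way.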